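The source may hold more compounds than are shown below. What is called first, only, known or untested is meant among the compounds shown, and "the series" means these compounds.

Of the compounds shown here, three that share one core have been measured in an assay on isolated protein (Bos taurus) with 5-hydroxytryptamine receptor 1D (Homo sapiens) as the target; on this read-out lower numbers stand for stronger inhibition and higher numbers for weaker inhibition. Compound 1 `c1ccc2c(c1)CCC(CNCCCNc1cnccn1)O2` gives 10 nM. Compound 2 `Clc1ccc(NCCCNCC2CCc3ccccc3O2)nn1` gives 2 nM, and compound 3 `c1ccc2c(c1)CCC(CNCCCNc1nccs1)O2` gives 7.94 nM. Among these three numbers compound 3 holds the second highest. The step of a 1.3-fold lower number from compound 1 to compound 3 (0.10 log units; within the scatter) lies within the scatter, whereas the step of a 4.0-fold higher number from compound 2 to compound 3 (0.60 log units; beyond the scatter) lies beyond it.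

Compound 4 `O=C1CCCN=C(NCCCNCC2CCc3ccccc3O2)N1` has not yet been measured in this assay. It differs from compound 3 by a group of 8 heavy atoms (5 carbon, 2 nitrogen, 1 oxygen; one seven-membered non-aromatic ring with 2 hetero atoms) in place of a group of 5 heavy atoms (3 carbon, 1 nitrogen, 1 sulfur; one five-membered aromatic ring with 2 hetero atoms), on an amine nitrogen. The measured steps that bear on this change are those at the same amine nitrogen: a 5.0-fold lower number from compound 1 to compound 2 (0.70 log units; beyond the scatter) and a 1.3-fold lower number from compound 1 to compound 3 (0.10 log units; within the scatter). Both exchanged one small heteroaromatic group for another and moved the number by no more than a modest amount. The group entering compound 4 is instead a seven-membered non-aromatic ring that counts one hydrogen-bond donor where the leaving group counts none, so the measured steps are only a loose guide and a modest shift in either direction cannot be excluded.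

Compound 4 is therefore expected to give about 15 nM in this assay, somewhere between 4 nM and 60 nM. The expected step is a 1.9-fold higher number from compound 3 to compound 4 (0.28 log units; within the scatter), a slightly higher number that may not clear the scatter.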

Compound 4, half-maximal inhibitory concentration: 158 nM
Compound 4: the middle estimate sits 11-fold (1.02 log units) below what was measured; the whole stated range lies below it.
By their numbers in this assay, from the lowest: compound 2; then compounds 3 and 1 (each within the scatter of the next); then compound 4.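

In this assay, among these compounds, this amine nitrogen proves far less permissive than the earlier compounds suggested: the seven-membered non-aromatic ring gives a 20-fold higher number from compound 3 to compound 4 (1.30 log units; beyond the scatter), while the comparison with the pyrazin-2-yl group gives a 16-fold higher number from compound 1 to compound 4 (1.20 log units; beyond the scatter) and that with the 6-chloropyridazin-3-yl group gives a 79-fold higher number from compound 2 to compound 4 (1.90 log units; beyond the scatter). The earlier exchanges among small aromatic rings at this nitrogen moved the number by a modest amount at most, so the change in compound 4 is the first one shown to cost a large step, and compound 4 has a higher number than all three compounds with aromatic rings. No measurement shown here gives a reason for this loss.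

Compound 4 differs from the 1,3-thiazol-2-yl compound in ring size, in having a non-aromatic ring and in carrying a hydrogen-bond donor, and these compounds cannot show which of those differences matters. From the compounds shown here alone, how a phenyl ring, a six-membered lactam ring or an open-chain urea on the same amine nitrogen would compare remains open.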